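The source may report more compounds than this note shows. Statements on the series, on what has been measured and on what is new or still open speak of the compounds shown alone.

Measured so far in a functional assay on RAW264.7 cells (Mus musculus) for inhibition, read by Griess assay, with stated times of 2 h and 24 h; on this read-out lower numbers stand for stronger inhibition and higher numbers for weaker inhibition:
compound 1 `COc1ccc([C@@H]2CC(=O)c3c(O)cc(OCc4cn(Cc5ccccc5Cl)nn4)cc3O2)cc1O` gives 6140 nM
compound 2 `CCCCn1cc(COc2cc(O)c3c(c2)O[C@H](c2ccc(OC)c(O)c2)C/C3=N\O)nn1` gives 8900 nM
compound 3 `COc1ccc([C@@H]2CC(=O)c3c(O)cc(OCc4cn(Cc5cccc(C(F)(F)F)c5)nn4)cc3O2)cc1O` gives 19900 nM

Compound 3 carries the highest of the three numbers in this assay; compound 2 lies nearest and compound 1 furthest, both gaps beyond the scatter. Compound 4 `COc1ccc([C@@H]2CC(=O)c3c(O)cc(OCc4cn(Cc5ccccc5F)nn4)cc3O2)cc1O` is not yet measured. It differs from compound 3 by 2-fluorophenyl in place of 3-(trifluoromethyl)phenyl on a saturated chain carbon bound to an aromatic nitrogen. Within the data shown here, the one measured step that bears on it is a 3.2-fold higher number from compound 1 to compound 3 (0.51 log units; beyond the scatter), which runs in the opposite direction to the change now made: compound 4, like compound 1, carries a single halogen on the phenyl ring in place of the trifluoromethyl. A return toward the number of compound 1 is therefore expected, a step of a 2.8-fold lower number from compound 3 to compound 4 (0.45 log units; beyond the scatter), because of a 3.2-fold higher number from compound 1 to compound 3 (0.51 log units; beyond the scatter). Compound 4 is estimated at 7000 nM, with a range from 3500 nM to 14000 nM.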

Compound 4, half-maximal inhibitory concentration: 7320 nM
Compound 4: middle estimate off by 1.0-fold (0.02 log units), on the low side; the measured number falls inside the stated range.
By their numbers in this assay, from the lowest: compounds 1, 4 and 2 (each within the scatter of the next); then compound 3.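

In this assay the change to 2-fluorophenyl gives a 2.7-fold lower number from compound 3 to compound 4 (0.43 log units; beyond the scatter) on this saturated chain carbon bound to an aromatic nitrogen, so the higher number of compound 3 is not common to all substituted benzyl groups here. Fluoro in place of chloro on an aromatic carbon gives a 1.2-fold higher number from compound 1 to compound 4 (0.08 log units; within the scatter) and thus separates neither halogen from the other on this read-out. No measurement offers an explanation for either step.

The compounds shown do not separate the trifluoromethyl group from its ring position, since 3-(trifluoromethyl)phenyl and 2-fluorophenyl differ in both. On these data alone, how a methoxy, an amine or a carboxylic acid on this phenyl ring would read remains open.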